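The source may hold more compounds than are shown below. What is called first, only, known or untested is meant among the compounds shown, and "the series" means these compounds.

compound 1 `COc1cccc(NC(=O)c2nnn(Cc3ccc([S+](C)[O-])cc3)c2N)c1` gives 0.5 mL.min-1.g-1
compound 2 `COc1cccc(NC(=O)c2nnn(CC3CCN(C(=O)OC(C)(C)C)CC3)c2N)c1` gives 10 mL.min-1.g-1

In an ADME assay on microsomes from liver (Mus musculus, strain CD1) for metabolic stability, read by HPLC, using NADPH, with a stated time of 30 min (a lower number here means slower removal, a higher number faster removal of the compound), compound 1 holds the lower of the two numbers, and compound 2 lies above it, beyond the scatter. Compound 3 `COc1cccc(NC(=O)c2nnn(Cc3ccc(-n4cccn4)cc3)c2N)c1` keeps the core of compound 1 but carries 1H-pyrazol-1-yl on an aromatic carbon, para to a large group a group of 5 heavy atoms (3 carbon, 2 nitrogen; one five-membered aromatic ring with 2 hetero atoms) in place of a group of 3 heavy atoms (1 carbon, 1 oxygen, 1 sulfur; no ring), on an aromatic carbon in the shared frame. Within the data shown here, no measured step covers this change, so the expectation rests only on compound 1 at 0.5 mL.min-1.g-1 and compound 2 at 10 mL.min-1.g-1 as the two readings available. What is expected is a 10-fold higher number from compound 1 to compound 3 (1.00 log units; beyond the scatter) as an upward move beyond the scatter. Compound 3 is estimated at 5 mL.min-1.g-1 (from 1.5 mL.min-1.g-1 to 15 mL.min-1.g-1).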

Compound 3, intrinsic clearance in microsomes: 2.3 mL.min-1.g-1
For compound 3 the middle estimate is 2.2-fold (0.34 log units) above the measured one, within the range that was stated.
By their numbers in this assay, from the lowest: compound 1; then compound 3; then compound 2.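

On the aromatic carbon para to a large group, 1H-pyrazol-1-yl in place of the group of 3 heavy atoms gives a modest rise in this assay (a 4.6-fold higher number from compound 1 to compound 3 (0.66 log units; beyond the scatter)), beyond the scatter. Among these compounds, this is the first measured step at this position, and it shows that the number responds to the group on that carbon while the core of compound 1 stays the same. No measurement shown here explains the step.

On these data alone, whether an amine or a carboxylic acid on that carbon would move the number the same way remains open. So does whether other five-membered aromatic rings would behave like 1H-pyrazol-1-yl.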